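Replacing an Aminophenyl Group: What to Expect for Compound 4

This account rests on a few compounds, and the source may have more. Where it says the series, first, only, none or still open, it means among the compounds named here.

Measured compounds:
compound 1, `COc1ccc(S(=O)(=O)N2CCc3cccc(-c4ccc(N)cc4)c32)cc1`, 249 nM
compound 2, `COc1ccc(S(=O)(=O)N2CCc3cccc(-c4ccc(F)c(F)c4)c32)cc1`, 45 nM
compound 3, `COc1ccc(S(=O)(=O)N2CCc3cccc(-c4ccncc4)c32)cc1`, 96 nM

In a functional assay on KB cells (Homo sapiens) for inhibition, with a stated time of 72 h (on this read-out higher numbers stand for weaker inhibition and lower numbers for stronger inhibition), compound 1 gives the highest of the three numbers shown, with compound 3 nearest and compound 2 furthest from it. The shared core carries a different aromatic group in each case, and both replacements of the 4-aminophenyl of compound 1 lowered the number: a 5.5-fold lower number from compound 1 to compound 2 (0.74 log units; beyond the scatter) and a 2.6-fold lower number from compound 1 to compound 3 (0.41 log units; beyond the scatter). Between the two newer groups the order is a 2.1-fold higher number from compound 2 to compound 3 (0.33 log units; beyond the scatter).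

Compound 4, `COc1ccc(S(=O)(=O)N2CCc3cccc(-c4cccc(F)c4)c32)cc1`, is the next member of this set and has not yet been measured. It differs from compound 1 in one place: 3-fluorophenyl in place of 4-aminophenyl on an aromatic carbon. Going by the values given here, the closest precedent is the step to compound 2, which also exchanged the 4-aminophenyl for a fluorine-bearing phenyl ring and gave a 5.5-fold lower number from compound 1 to compound 2 (0.74 log units; beyond the scatter); the step to compound 3, a 2.6-fold lower number from compound 1 to compound 3 (0.41 log units; beyond the scatter), points the same way. Compound 4 carries a single fluorine rather than two, so a step smaller than that to compound 2 but still beyond the scatter is expected, in the direction of a lower number. Compound 4 is therefore estimated at 75 nM, within a range of 30 nM to 180 nM, which would mean a step of a 3.3-fold lower number from compound 1 to compound 4 (0.52 log units; beyond the scatter).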

Compound 4, half-maximal inhibitory concentration: 98.5 nM
For compound 4 the middle estimate is 1.3-fold (0.12 log units) below the measured one; the measured number falls inside the stated range.
By their numbers in this assay, from the lowest: compound 2; then compounds 3 and 4 (each within the scatter of the next); then compound 1.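

Compound 4 gives a third replacement of the 4-aminophenyl of compound 1 that lowers the number, a 2.5-fold lower number from compound 1 to compound 4 (0.40 log units; beyond the scatter), and it does so with a single fluorine on the ring and with 0 hydrogen-bond donors in the entering group. Going by these compounds alone, the comparison with compound 2 adds what the earlier compounds could not show, the effect of one fluoro group alone: with hydrogen in place of fluoro, turning the 3,4-difluorophenyl into the 3-fluorophenyl, there is a 2.2-fold higher number from compound 2 to compound 4 (0.34 log units; beyond the scatter), so the ring with two fluorines stays ahead of the ring with one, while a 1.0-fold higher number from compound 3 to compound 4 (0.01 log units; within the scatter) leaves 3-fluorophenyl and pyridin-4-yl indistinguishable at this place on the shared core. Nothing among the data given accounts for any of these steps.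

The compounds shown leave open how a 4-fluorophenyl would compare with the 3-fluorophenyl of compound 4, and so whether the place of a single fluorine on the ring matters at all. They also leave open whether a chloro, methoxy or nitrile group on the same phenyl ring would follow the fluoro group or the amine.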